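Five-membered heteroaryl swap: thiophene to furan

The source may hold more compounds than are shown below. What is called first, only, known or untested is meant among the compounds shown, and "the series" means these compounds.

Measured so far in a functional assay on HCT-15 cells (Homo sapiens) for cytotoxicity, read by CCK-8 assay and cell counting, with a stated time of 2 days; on this read-out higher numbers stand for weaker inhibition and lower numbers for stronger inhibition:
compound 1 `Oc1cccc(-c2cc(-c3cccs3)nc(-c3ccccc3Cl)c2)c1` gives 2790 nM
compound 2 `Oc1cccc(-c2cc(-c3ccsc3)nc(-c3ccccc3Cl)c2)c1` gives 2500 nM

Compound 2 and compound 1 differ only in the five-membered ring on the shared core, and their numbers cannot be told apart: a 1.1-fold lower number from compound 1 to compound 2 (0.05 log units; within the scatter). So compound 2 stands level with the only other measured compound, with nothing in the series yet moving the read-out beyond the scatter.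

Compound 3 `Oc1cccc(-c2cc(-c3ccco3)nc(-c3ccccc3Cl)c2)c1` continues at the same position: furan-2-yl in place of thiophen-3-yl on an aromatic carbon. Going by the values given here, the one measured step that bears on this place, a 1.1-fold lower number from compound 1 to compound 2 (0.05 log units; within the scatter), changed a five-membered ring of the same kind without effect, so for compound 3 no step beyond the scatter is expected in this assay, in either direction. Compound 3 is therefore estimated at 2600 nM, with a range of 1200 nM to 6000 nM, corresponding to an expected 1.0-fold higher number from compound 2 to compound 3 (0.02 log units; within the scatter).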

Compound 3, half-maximal inhibitory concentration: 2230 nM
For compound 3 the middle estimate is 1.2-fold (0.07 log units) above the measured one, and the stated range covers the measured number.
By their numbers in this assay, from the lowest: compounds 3, 2 and 1 (each within the scatter of the next).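

With furan-2-yl on the aromatic carbon next to the ring nitrogen, the ring hetero atom changes from sulfur to oxygen, and the read-out in this assay still does not move: a 1.1-fold lower number from compound 2 to compound 3 (0.05 log units; within the scatter) and a 1.3-fold lower number from compound 1 to compound 3 (0.10 log units; within the scatter) are the two new steps. The earlier pair varied only the attachment point of the thiophene, whereas these steps extend the level result to a different hetero atom, so all three five-membered aromatic rings stand within the scatter of one another. No evidence is at hand that would account for this level result.

The compounds shown leave open whether an amine, a carboxylic acid or a longer alkyl chain at this position would shift the number beyond the scatter. From the compounds shown here alone, the 2-chlorophenyl and 3-hydroxyphenyl groups stay constant throughout, so their contribution to the read-out also remains open.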